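This account rests on a few compounds, and the source may have more. Where it says the series, first, only, none or still open, it means among the compounds named here.

Measured so far:
- compound 1 `O=C(/C=C(/C=C/c1ccc(O)cc1)NCCCO)/C=C/c1ccc(O)cc1`: 128000 nM
- compound 2 `COCCNC(=C\C(=O)/C=C/c1ccc(O)c(OC)c1)/C=C/c1ccc(O)c(OC)c1`: 12700 nM

Both values come from a physicochemical assay for solubility, using the shake flask method, in phosphate buffer, with a stated time of 24 h, at pH 6.8; on this read-out higher numbers stand for higher solubility and lower numbers for lower solubility. Compound 1 holds the higher of the two numbers. The gap separating the two compounds lies beyond the usual scatter of repeat measurements. These two compounds differ in more than one place, so their gap says nothing about any single structural change.

Next in line is compound 3 `O=C(/C=C(/C=C/c1ccc(O)cc1)NCCO)/C=C/c1ccc(O)cc1`, not yet measured in this assay. Its difference from compound 1 is hydroxy in place of hydroxymethyl on a saturated chain carbon, two bonds along the chain from an amine nitrogen. The same difference reads as 3-hydroxypropyl to 2-hydroxyethyl.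

Among the compounds with values here, the series holds no measured pair that differs in one place only, so no measured step sizes this change. Within the data shown here, the only anchor is compound 1 at 128000 nM. The estimated 1.1-fold lower number from compound 1 to compound 3 (0.03 log units; within the scatter) is expected to stay within the scatter, with no direction favoured. For compound 3 the expected value is 120000 nM, with an estimated range of 50000 nM to 280000 nM.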

Compound 3, solubility: 37900 nM
Beside the measured number, compound 3's estimate is 3.2-fold (0.50 log units) above it; measured number outside the range, below it.
By their numbers in this assay, from the lowest: compound 2; then compound 3; then compound 1.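

In this assay, within the data shown here, the series now has its first step at a single place: going from 3-hydroxypropyl to 2-hydroxyethyl on the amine nitrogen gives a 3.4-fold lower number from compound 1 to compound 3 (0.53 log units; beyond the scatter) and so sizes a change that no earlier pair could. This position on the chain therefore registers in the read-out, even though the change removes only one carbon and leaves the counts of hydrogen-bond donors and acceptors in the exchanged groups the same. No measurement to hand accounts for the size or direction of this step.

The compounds shown leave open how a longer chain such as 4-hydroxybutyl would read at this place, and so whether one step marks a trend with chain length, as well as how an amine or a carboxylic acid would read in place of the hydroxy. From the compounds shown here alone, compound 2 differs from compound 3 in more than one place, so it also remains open whether the same step would hold on the core of compound 2.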